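This account rests on a few compounds, and the source may have more. Where it says the series, first, only, none or still open, it means among the compounds named here.

Compound 1 `CCOC(=O)c1c(-c2cccc(F)c2)[nH]c2cc(OC)ccc2c1=O` carries a 3-fluorophenyl group on the shared core. In a physicochemical assay for solubility, in phosphate buffer, at pH 7.4 (on this read-out lower numbers stand for lower solubility and higher numbers for higher solubility), compound 1 gives > 100000 nM, which is a limit of the assay and not a number. Compound 2 `CCOC(=O)c1c(-c2cccc([N+](=O)[O-])c2)[nH]c2cccc(OC)c2c1=O` gives 49000 nM in this assay. Compound 3 `CCOC(=O)c1c(-c2ccccc2C)[nH]c2cccc(OC)c2c1=O` gives > 100000 nM, again a limit. Among the compounds with values here, the only measured step, an at least 2.0-fold higher number from compound 2 to compound 3 (0.30 log units; that floor lies within the scatter), concerns a different pair of groups, and the picture is shaped by the limit of > 100000 nM in this assay, at which 2 of the 3 values shown sit. Within the data shown here, the change to compound 4 `CCOC(=O)c1c(-c2ccc(Cl)c(Cl)c2)[nH]c2cc(OC)ccc2c1=O` is 3,4-dichlorophenyl in place of 3-fluorophenyl on an aromatic carbon, for which no measured step exists here, so no direction beyond the scatter can be drawn from the data. Compound 4 is expected to give 30000 nM, with a range from 8000 nM to 100000 nM. The expected step is an at least 3.3-fold lower number from compound 1 to compound 4 (0.52 log units; beyond the scatter).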

Compound 4, solubility: 17000 nM
For compound 4 the middle estimate is 1.8-fold (0.25 log units) above the measured one; low and high end bracket the measured number.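

In this assay, 3,4-dichlorophenyl in place of 3-fluorophenyl at this position gives an at least 5.8-fold lower number from compound 1 to compound 4 (0.76 log units; beyond the scatter). This is the first step shown that clearly lies beyond the scatter, and compound 4 gives a measured number on the core of compound 1, where the earlier value was only a limit. The size of the step is therefore only a floor, and the real step may be larger: the limit of > 100000 nM in this assay, at which 2 of the 4 values shown sit.

The compounds shown leave open whether one chlorine alone would bring the same drop. They also leave open how an amine or a carboxylic acid on this phenyl ring would read.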